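A chloro for a methyl on the shared core

The compounds below may be only part of what the source reports. "The series", "measured", "known", "first", "only" and "open" are said of these compounds alone.

compound 1 `COc1ccc(C(N)=O)cc1/C=C/c1cccc(C)c1` gives 3900 nM
compound 2 `COc1ccc(C(N)=O)cc1/C=C/c1ccccc1C` gives 2300 nM

Both values come from a functional assay on HUVEC cells (Homo sapiens) for inhibition, with a stated time of 4 days (on this read-out higher numbers stand for weaker inhibition and lower numbers for stronger inhibition), and, once the usual scatter is allowed for, compound 2 at 2300 nM stands level with compound 1 at 3900 nM in this small set. Compound 3 `COc1ccc(C(N)=O)cc1/C=C/c1ccccc1Cl` has not yet been measured and differs from compound 2 in one place, with chloro in place of methyl on an aromatic carbon, ortho to a large group (chloro in place of methyl on an aromatic carbon). For the measured compounds named here, no measured pair shows this change, so the data offer no direct precedent. The expectation rests on compound 2 at 2300 nM as the nearest measured neighbour. What is expected is a 1.1-fold higher number from compound 2 to compound 3 (0.04 log units; within the scatter) in this assay and no step beyond the scatter, in neither direction. For compound 3 the estimated value is 2500 nM with an expected range from 1100 nM to 5500 nM as the likely span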

Compound 3, half-maximal inhibitory concentration: 23000 nM
For compound 3 the middle estimate is 9.2-fold (0.96 log units) below the measured one, outside the stated range (above it).
By their numbers in this assay, from the lowest: compounds 2 and 1 (each within the scatter of the next); then compound 3.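

In this assay chloro in place of methyl on an aromatic carbon, ortho to a large group, is not a neutral exchange at this position: it gives a 10-fold higher number from compound 2 to compound 3 (1.00 log units; beyond the scatter) and so weakens inhibition. Methyl and chloro match in heavy atom count, and neither brings a ring, a hydrogen-bond donor or acceptor, or a net charge, so these counts do not separate two groups that the read-out clearly does separate. Nothing measured here accounts for the step.

The compounds shown leave open whether weaker inhibition comes with chloro alone or would also follow from fluoro, methoxy or a nitrile at this place. They also leave open whether chloro in place of the methyl of compound 1 would bring a step of similar size.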